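Ethylsulfanyl in place of prop-1-en-1-yl on the shared core

The compounds below may be only part of what the source reports. "The series", "measured", "known", "first", "only" and "open" are said of these compounds alone.

Within the data shown here, in a functional assay (aorta) with Oryctolagus cuniculus as the target (a lower number here means tighter binding, a higher number weaker binding), compound 2 `C/C=C/c1nc2c(C)ccnc2n1Cc1ccc(-c2ccccc2C(=O)O)cc1` gives 5.01 nM and holds the lower of the two numbers so far, against compound 1 `Cc1ccnc2c1nc(C(C)C)n2Cc1ccc(-c2ccccc2C(=O)O)cc1` at 31.6 nM on the same read-out. Compound 3 `CCSc1nc2c(C)ccnc2n1Cc1ccc(-c2ccccc2C(=O)O)cc1` carries ethylsulfanyl in place of prop-1-en-1-yl on an aromatic carbon. Among the measured compounds shown here, only one measured step bears on that place, a 6.3-fold lower number from compound 1 to compound 2 (0.80 log units; beyond the scatter) and modest in size, and no measured compound carries ethylsulfanyl. A modest rise is therefore expected, with the estimated step being a 2.4-fold higher number from compound 2 to compound 3 (0.38 log units; beyond the scatter) in this assay and its direction uncertain. For compound 3 the estimated value is 12 nM with an expected range from 3 nM to 45 nM as the likely span.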

Compound 3, dissociation constant: 5.01 nM
Estimate against measurement, compound 3: 2.4-fold (0.38 log units) above; the measured number falls inside the stated range.
By their numbers in this assay, from the lowest: compounds 2 and 3 (each within the scatter of the next); then compound 1.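

In this assay the change at this aromatic carbon gives no change at the digits printed from compound 2 to compound 3 (within the scatter) and so shows that a second group, one with sulfur in its chain and no double bond outside aromatic rings, sits level with prop-1-en-1-yl. Set against isopropyl, ethylsulfanyl gives a 6.3-fold lower number from compound 1 to compound 3 (0.80 log units; beyond the scatter) and thus the lower number at this place does not depend on that double bond. No evidence is available to explain why the two groups match. From the compounds shown here alone, whether an amine, a methoxy group or a longer chain such as butyl would hold the number here remains open.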